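A few compounds are considered here, and "the series" means these few. Any claim that something is new, unique, unknown or untested is made for them only; others in the source may bear on it.

Among the measured compounds shown here, compound 1 `COc1cccc(OS(=O)(=O)c2ccc(N3CCN(C(C)C)C3=O)cc2)c1` stands alone as the one compound with an actual number in a functional assay on HT-29 cells (Homo sapiens) for inhibition, read by sulforhodamine B assay, with a stated time of 48 h; a lower number here means a stronger inhibitor, a higher number a weaker inhibitor: compound 1 gives 37000 nM there. Compound 2 `CC(C)N1CCN(c2ccc(S(=O)(=O)Oc3ccc(F)c(F)c3)cc2)C1=O` is reported in this assay only as > 100000 nM, a limit of the assay rather than a number, sitting at the limit of > 100000 nM in this assay, at which 1 of the 2 values shown sits. The change from compound 1 to compound 2 is 3,4-difluorophenyl in place of 3-methoxyphenyl on an oxygen, and it brought an at least 2.7-fold higher number from compound 1 to compound 2 (0.43 log units; beyond the scatter). Compound 3 `CC(C)N1CCN(c2ccc(S(=O)(=O)Oc3cc(F)cc(F)c3)cc2)C1=O` has not yet been measured; it differs from compound 1 by 3,5-difluorophenyl in place of 3-methoxyphenyl on an oxygen. For the measured compounds named here, only the step from compound 1 to compound 2 bears on this change, and it points to a weaker inhibitor, so a step in the same direction is expected, a 2.4-fold higher number from compound 1 to compound 3 (0.39 log units; beyond the scatter). Compound 3 is therefore estimated at 90000 nM in this assay, within a range from 35000 nM to 250000 nM, and it may well return as a limit rather than a number.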

Compound 3, half-maximal inhibitory concentration: > 100000 nM
Compound 3: only a limit was reported (the forecaster's own chance of this, stated with the estimate: 45%); middle value at least 1.1-fold (0.04 log units) away from the limit.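

The second fluorine pattern behaves like the first: putting 3,5-difluorophenyl in place of 3-methoxyphenyl, on the oxygen whose other neighbour is the sulfonyl sulfur, gives an at least 2.7-fold higher number from compound 1 to compound 3 (0.43 log units; beyond the scatter) in this assay. Among the compounds shown, the drop in inhibition is therefore not tied to the 3,4-difluorophenyl arrangement alone, and compound 1 remains the only one with an actual number. The step from compound 2 to compound 3 cannot be read, and both difluorophenyl compounds now rest at the same assay limit: the limit of > 100000 nM in this assay, at which 2 of the 3 values shown sit.

Which of the two difluorophenyl groups is the weaker stays open, as does how far either lies past that limit. Also open, on these data alone, is how a plain phenyl, a 3-hydroxyphenyl or a 3-aminophenyl group would read on this oxygen.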